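The source may report more compounds than this note shows. Statements on the series, on what has been measured and on what is new or still open speak of the compounds shown alone.

Measured compounds:
Compound 1, `C=C1C(=O)OC[C@@H]1CCOC(=O)Nc1ccc(C(C)C)cc1`: 15300 nM
Compound 2, `C=C1C(=O)OC[C@@H]1CCOC(=O)Nc1ccccc1`: 22300 nM

In an ADME assay on RAW264.7 cells (Mus musculus) for cytotoxicity, read by MTT assay, with a stated time of 18 h (on this read-out higher numbers stand for lower toxicity in this test and lower numbers for higher toxicity in this test), compound 2 gives 22300 nM, the higher of the two numbers recorded so far. Its nearest neighbour is compound 1, and the step of a 1.5-fold higher number from compound 1 to compound 2 (0.16 log units; within the scatter) stays within the scatter of repeated measurements, so the two compounds cannot be told apart on this read-out.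

Compound 3, `C=C1C(=O)OC[C@@H]1CCOC(=O)Nc1ccc(C(=O)OCCCC)cc1`, has not yet been measured. It differs from compound 2 in one place: butoxycarbonyl in place of hydrogen on an aromatic carbon. Among the measured compounds shown here, the only measured step that bears on this change is the one from compound 1 to compound 2, in which a substituent at the same aromatic position was exchanged for hydrogen; that step, a 1.5-fold higher number from compound 1 to compound 2 (0.16 log units; within the scatter), did not move the number beyond the scatter. For the measured compounds named here, with only that single comparison to go on, no step beyond the scatter is expected in this assay from adding butoxycarbonyl, in either direction. Compound 3 is therefore expected to give 18000 nM, with a range of 7000 nM to 45000 nM, which means an estimated step of a 1.2-fold lower number from compound 2 to compound 3 (0.09 log units; within the scatter).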

Compound 3, half-maximal cytotoxic concentration: 12700 nM
The estimate for compound 3 lay 1.4-fold (0.15 log units) above the measured number, and the stated range covers the measured number.
By their numbers in this assay, from the lowest: compounds 3, 1 and 2 (each within the scatter of the next).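

Compound 3 carries a far bigger substituent than the isopropyl of compound 1, with 7 heavy atoms and 2 hydrogen-bond acceptors, yet in this assay butoxycarbonyl in place of hydrogen gives a 1.8-fold lower number from compound 2 to compound 3 (0.24 log units; within the scatter), and butoxycarbonyl in place of isopropyl gives a 1.2-fold lower number from compound 1 to compound 3 (0.08 log units; within the scatter). The earlier pair had shown only that isopropyl and hydrogen could not be told apart; this result extends that finding to a chain holding a carbonyl, so on an aromatic carbon para to a large group, all three substituents remain indistinguishable on this read-out. Nothing available gives a reason for this flat result or shows what lies behind these numbers.

Whether an amine, a carboxylic acid or a longer chain at this place would produce a step beyond the scatter remains open, since hydrogen, isopropyl and butoxycarbonyl are the only groups shown there. Also open, as far as these compounds go, is whether butoxycarbonyl would behave the same way elsewhere on the aromatic ring, or whether any change to the shared core would move the number further than these substitutions have.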